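Replacing 4-fluorophenyl with 3-chlorophenyl in compound 1

The source may report more compounds than this note shows. Statements on the series, on what has been measured and on what is new or still open speak of the compounds shown alone.

- Compound 1 `O=C1C(=Cc2ccc(F)cc2)C(=O)N(c2ccc(Cl)cc2)N1c1ccc(Cl)cc1` gives 35600 nM
- Compound 2 `COc1cc(C=C2C(=O)N(c3ccc(Cl)cc3)N(c3ccc(Cl)cc3)C2=O)cc(OC)c1OC` gives 10100 nM

Both compounds were tested in a functional assay on ECa-109 cells (Homo sapiens) for cytotoxicity, read by MTT assay, with a stated time of 72 h (a higher number here means a weaker inhibitor, a lower number a stronger inhibitor), and share the core of compound 1. Compound 1 stands highest of the two at 35600 nM and is thus the weaker inhibitor, while compound 2 lies lower at 10100 nM with a gap beyond the scatter.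

Compound 3 `O=C1C(=Cc2cccc(Cl)c2)C(=O)N(c2ccc(Cl)cc2)N1c1ccc(Cl)cc1` has not yet been measured. It has 3-chlorophenyl in place of 4-fluorophenyl on a double-bonded chain carbon bound to a double-bonded ring carbon.

Within the data shown here, the data hold no measured step for this exchange, so the expectation remains cautious. In this assay a small shift toward a lower number is expected, with no step beyond the scatter (a 1.5-fold lower number from compound 1 to compound 3 (0.17 log units; within the scatter)). Compound 3 is estimated at 24000 nM (expected range 8000 nM to 60000 nM).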

Compound 3, half-maximal inhibitory concentration: 22600 nM
For compound 3 the middle estimate is 1.1-fold (0.03 log units) above the measured one, within the range that was stated.
By their numbers in this assay, from the lowest: compound 2; then compounds 3 and 1 (each within the scatter of the next).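

In this assay, putting 3-chlorophenyl in place of 4-fluorophenyl on a double-bonded chain carbon bound to a double-bonded ring carbon gives a 1.6-fold lower number from compound 1 to compound 3 (0.20 log units; within the scatter), a step that stays within the usual scatter. The result shows that, on the core of compound 1, these two singly halogenated phenyl groups can stand in for each other at this position without a difference beyond the scatter. No measurement at hand offers an explanation for this result.

The exchange alters both the halogen and its place on the ring, so the compounds shown cannot separate the two; 3-fluorophenyl or 4-chlorophenyl would do so. From the compounds shown here alone, it also remains open how a phenyl ring carrying an amine or a carboxylic acid would behave at this position.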